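Cytotoxicity notes on the pendant aryl substituent series

A few compounds are considered here, and "the series" means these few. Any claim that something is new, unique, unknown or untested is made for them only; others in the source may bear on it.

Compound 3 `N#Cc1ccc(-c2csc(N3N=C(c4ccc(Cl)s4)CC3c3ccc(F)cc3)n2)cc1` is known in an ADME assay on NIH3T3 cells (Mus musculus) for cytotoxicity, read by XTT assay, with a stated time of 24 h (a lower number here means a stronger inhibitor, a higher number a weaker inhibitor), only as a limit: compound 3 gives > 500 ug/mL. Compound 1 `Fc1ccc(C2CC(c3ccc(Cl)s3)=NN2c2nc(-c3ccc(Cl)cc3)cs2)cc1` likewise reaches only a limit, compound 1 giving > 500 ug/mL. Compound 2 `CS(=O)(=O)c1ccc(-c2csc(N3N=C(c4ccc(Cl)s4)CC3c3ccc(F)cc3)n2)cc1` also ends at a limit; in this assay compound 2 gives > 500 ug/mL. The steps among these three cannot be sized: a step that the two limits leave unreadable from compound 1 to compound 2, a step that the two limits leave unreadable from compound 1 to compound 3 and a step that the two limits leave unreadable from compound 2 to compound 3. For the measured compounds named here, every value so far sits at one place, (the limit of > 500 ug/mL in this assay, at which 3 of the 3 values shown sit).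

Compound 4 `Fc1ccc(C2CC(c3ccc(Cl)s3)=NN2c2nc(-c3ccccc3)cs2)cc1` differs from compound 3 in one place: hydrogen in place of cyano on an aromatic carbon. The measured steps that bear on this exchange are those from compound 1 to compound 3 and from compound 2 to compound 3, each swapping the group on the same aromatic carbon, and each stays unreadable because of the limit of > 500 ug/mL in this assay, at which 3 of the 3 values shown sit. Going by the values given here, no step of readable size is therefore expected in this assay; compound 4 is expected to remain at the limit, with an expected step that the limit leaves unreadable from compound 3 to compound 4. The estimate for compound 4 is 700 ug/mL, expected to fall between 400 ug/mL and 1500 ug/mL.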

Compound 4, half-maximal inhibitory concentration: > 500 ug/mL
Compound 4: a limit, no number; the forecaster's own chance of this, stated with the estimate: 85%; the middle value is on the limit's open side.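

Compound 4 also ends at a limit, so its steps from compound 1, compound 2 and compound 3 cannot be read: the limit of > 500 ug/mL in this assay, at which 4 of the 4 values shown sit.

The compounds shown leave open whether chloro, methylsulfonyl, cyano and hydrogen on this aromatic carbon differ at all in this assay, as none of them gives a number there.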